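The compounds below may be only part of what the source reports. "The series", "measured", "known", "first", "only" and "open" are said of these compounds alone.

Measured compounds:
- compound 1, `CS(=O)(=O)Oc1c(C(=O)NCc2ccc(F)cc2)nc(Br)c2cccnc12`: "not determined" (no result reported)
- compound 2, `CC(C)(C)OC(=O)N1CCN(c2c(C(=O)NCc3ccc(F)cc3)nc(Br)c3cccnc23)CC1`: > 10000 nM
- compound 3, `N[C@H]1CC[C@H](Nc2c(C(=O)NCc3ccc(Cl)cc3Cl)nc(Br)c3cccnc23)CC1`: "not determined" (no result reported)

These three share a core and differ in the group fixed on one aromatic carbon and in the benzyl amide. In a functional assay on MCF7 cells (Homo sapiens) for cytotoxicity, read by MTT assay, with a stated time of 72 h (on this read-out higher numbers stand for weaker inhibition and lower numbers for stronger inhibition), compound 1 has no recorded number, so there is nothing to place it against. Compound 2 carries a tert-butoxycarbonyl-piperazine at that carbon, and in this assay compound 2 reaches only the limit of the assay, > 10000 nM. That limit is the only measured entry among the three, as the summary the limit of > 10000 nM in this assay, at which 1 of the 3 values shown sits, notes. Compound 3, with a diaminocyclohexyl group and a dichlorobenzyl amide, likewise has no recorded number in this assay.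

The compound still to be measured is compound 4, `NCCCCCCNc1c(C(=O)NCc2ccc(F)cc2)nc(Br)c2cccnc12`. It differs from compound 1 in one place: (6-aminohexyl)amino in place of (methylsulfonyl)oxy on an aromatic carbon. Within the data shown here, because compound 1 has no value, the size and direction of the step in this assay cannot be read from the data, and no step between measured compounds exists to compare it with. Among the measured compounds shown here, the only anchor is that compound 2 gives > 10000 nM, a limit. On that basis compound 4 is expected to give around 6000 nM in this assay, with a likely span from 600 nM to 40000 nM, and a real chance that only a limit is reported.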

Compound 4, half-maximal inhibitory concentration: 2000 nM
Compound 4: the middle estimate sits 3.0-fold (0.48 log units) above what was measured; low and high end bracket the measured number.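

No step can be read from compound 1 to compound 4, although they differ in only one place: in this assay, compound 1 gives "not determined" (no result reported), which leaves no number to compare. The compounds shown leave open whether (6-aminohexyl)amino gives stronger or weaker inhibition than (methylsulfonyl)oxy on the shared core.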